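The source may hold more compounds than are shown below. What is called first, only, known or untested is meant among the compounds shown, and "the series" means these compounds.

In a functional assay (strain AB) with Danio rerio as the target, read by microscopy, with a stated time of 1 h (on this read-out higher numbers stand for an effect only at larger amounts of compound and lower numbers for an effect already at smaller amounts), compound 1 `NC(=O)c1c(NC(=O)Nc2ccc(Cl)cc2)sc2c1CCN(CC1CCCCC1)C2` gives 1890 nM, compound 2 `CC(C)(C)CN1CCc2c(sc(NC(=O)Nc3ccc(Cl)cc3)c2C(N)=O)C1` gives 5560 nM and compound 3 `NC(=O)c1c(NC(=O)Nc2ccc(Cl)cc2)sc2c1CCN(CC1CCCC1)C2` gives 1830 nM. Compound 3 shares the low end of these numbers with its nearest neighbour (a 1.0-fold lower number from compound 1 to compound 3 (0.01 log units; within the scatter)) and lies a modest gap from the furthest (a 3.0-fold lower number from compound 2 to compound 3 (0.48 log units; beyond the scatter)). Compound 4 `CC(C)(C)OC(=O)CCCN1CCc2c(sc(NC(=O)Nc3ccc(Cl)cc3)c2C(N)=O)C1` carries this change: 2-(tert-butoxycarbonyl)ethyl in place of cyclopentyl on a saturated chain carbon bound to an amine nitrogen in a ring. Only changes at this same place bear on it, and the largest are modest: a 2.9-fold higher number from compound 1 to compound 2 (0.47 log units; beyond the scatter), alongside the step to compound 3 already given. Among the measured compounds shown here, no measured compound carries a tert-butoxycarbonyl group, so the expectation is loose. In this assay, the expected step is a 1.9-fold higher number from compound 3 to compound 4 (0.28 log units; within the scatter), modest and towards a higher number. Compound 4 is estimated at 3500 nM, with an expected range of 1300 nM to 10000 nM.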

Compound 4, half-maximal effective concentration: 560 nM
Compound 4: the middle estimate sits 6.3-fold (0.80 log units) above what was measured; the measured number lies below the stated range.
By their numbers in this assay, from the lowest: compound 4; then compounds 3 and 1 (each within the scatter of the next); then compound 2.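

In this assay, this assay, 2-(tert-butoxycarbonyl)ethyl at this position gives a lower number than each of the other groups (a 3.3-fold lower number from compound 3 to compound 4 (0.51 log units; beyond the scatter); a 3.4-fold lower number from compound 1 to compound 4 (0.53 log units; beyond the scatter); a 9.9-fold lower number from compound 2 to compound 4 (1.00 log units; beyond the scatter)). Among the compounds shown here, the earlier groups here are all carbon only and none goes lower than the cyclopentyl and cyclohexyl pair, so this open chain with 2 oxygen atoms and 2 hydrogen-bond acceptors is the first to do so. No evidence at hand accounts for this step.

From the compounds shown here alone, it remains open whether the chain or its tert-butoxycarbonyl end carries the step. A carboxylic acid, a methyl ester or a plain butyl chain at this place would help separate the two.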